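From fluoro to phenyl: what compound 4 may show

The source may report more compounds than this note shows. Statements on the series, on what has been measured and on what is new or still open speak of the compounds shown alone.

Measured so far in a functional assay on HepG2 cells (Homo sapiens) for antiproliferative activity, read by MTT assay, with a stated time of 48 h; a lower number here means a stronger inhibitor, a higher number a weaker inhibitor:
- compound 1 `COc1ccc(/C=C/c2cc(OC)cc(OC)c2/C=C/C(=O)c2ccc(C)cc2)cc1` gives 4.8 ug/mL
- compound 2 `COc1ccc(/C=C/c2cc(OC)cc(OC)c2/C=C/C(=O)c2ccc(Br)cc2)cc1` gives 12.9 ug/mL
- compound 3 `COc1ccc(/C=C/c2cc(OC)cc(OC)c2/C=C/C(=O)c2ccc(F)cc2)cc1` gives 12.2 ug/mL

Compound 3 stands with compound 2 at the upper end of these three numbers, and the two cannot be told apart (a 1.1-fold lower number from compound 2 to compound 3 (0.02 log units; within the scatter)). Compound 1 holds the lowest number (a 2.5-fold higher number from compound 1 to compound 3 (0.41 log units; beyond the scatter)).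

Compound 4 `COc1ccc(/C=C/c2cc(OC)cc(OC)c2/C=C/C(=O)c2ccc(-c3ccccc3)cc2)cc1` has not yet been measured. It departs from compound 3 in one place phenyl in place of fluoro on an aromatic carbon and the change is phenyl in place of fluoro on an aromatic carbon, para to a large group.

All three measured steps sit at that same carbon. Bromo in place of methyl was a modest step (a 2.7-fold higher number from compound 1 to compound 2 (0.43 log units; beyond the scatter)), and fluoro in place of methyl was about the same size. Fluoro in place of bromo made no difference beyond the scatter. None of these compounds carries a ring at this carbon, so the data give only a loose guide to phenyl, and no clear direction. For this assay the estimated change is small (a 1.2-fold lower number from compound 3 to compound 4 (0.09 log units; within the scatter)), so no step beyond the scatter is expected. The estimated value for compound 4 is 10 ug/mL with an expected range of 4 ug/mL to 25 ug/mL at this stage.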

Compound 4, half-maximal inhibitory concentration: 10.5 ug/mL
Estimate against measurement, compound 4: 1.1-fold (0.02 log units) below; the range from low to high includes it.
By their numbers in this assay, from the lowest: compound 1; then compounds 4, 3 and 2 (each within the scatter of the next).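

Among the compounds shown here, with phenyl, this carbon carries a ring for the first time, and in this assay the six heavy atoms that enter in place of the single fluorine leave no step beyond the scatter, with a 1.2-fold lower number from compound 3 to compound 4 (0.07 log units; within the scatter) and, against bromo, a 1.2-fold lower number from compound 2 to compound 4 (0.09 log units; within the scatter) as the readings. Compounds 2, 3 and 4 therefore form one group despite the large difference in the size of their substituents, and only the methyl of compound 1 stands apart, with a 2.2-fold higher number from compound 1 to compound 4 (0.34 log units; beyond the scatter) as a modest step beyond the scatter that shows the lower number of compound 1 is not matched by the ring. The change from fluoro to phenyl thus shows that the number at this carbon does not simply follow the count of heavy atoms, while no measurement at hand explains why methyl differs from the other three groups.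

As far as these compounds go, it remains open whether the lower number belongs to methyl alone or would also appear with ethyl, a longer chain, or a methoxy group at this carbon. From the compounds shown here alone, it is equally open where an amine or a carboxylic acid at this carbon would fall, or a substituent on the new phenyl ring.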